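From a 4-carboxyphenyl limit to a 3-methylphenyl estimate

This account rests on a few compounds, and the source may have more. Where it says the series, first, only, none or still open, it means among the compounds named here.

Of the compounds shown here, three with a shared core have been measured in a functional assay (aorta) with Rattus norvegicus as the target; a higher number here means a weaker inhibitor, a lower number a stronger inhibitor. Compound 1 `CC1(C)Oc2ccc(C#N)cc2[C@@H](/N=C(\NC#N)Nc2cccc(C(F)(F)F)c2)[C@@H]1O`, carrying 3-(trifluoromethyl)phenyl, gives 1600 nM. Compound 2 `CC(=O)c1ccc(N/C(=N/[C@@H]2c3cc(C#N)ccc3OC(C)(C)[C@H]2O)NC#N)cc1`, carrying 4-acetylphenyl, gives 21000 nM. Compound 3 `CC1(C)Oc2ccc(C#N)cc2[C@@H](/N=C(\NC#N)Nc2ccc(C(=O)O)cc2)[C@@H]1O`, carrying 4-carboxyphenyl, is reported only as a limit, > 100000 nM. Compound 3 thus stands at the limit of > 100000 nM in this assay, at which 1 of the 3 values shown sits.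

Compound 4 `Cc1cccc(N/C(=N/[C@@H]2c3cc(C#N)ccc3OC(C)(C)[C@H]2O)NC#N)c1`, not yet measured, has 3-methylphenyl in place of 4-carboxyphenyl on an amine nitrogen.

Within the data shown here, three measured steps bear on this change. Replacing 3-(trifluoromethyl)phenyl with 4-acetylphenyl brought a 13-fold higher number from compound 1 to compound 2 (1.12 log units; beyond the scatter). Replacing it with 4-carboxyphenyl brought an at least 62-fold higher number from compound 1 to compound 3 (1.79 log units; beyond the scatter). Hydroxy in place of methyl on the carbonyl carbon brought an at least 4.7-fold higher number from compound 2 to compound 3 (0.67 log units; beyond the scatter). Compound 4 gives up the 4-carboxyphenyl group, and its 3-methylphenyl group is closest by name to the group of compound 1, so most of an at least 62-fold higher number from compound 1 to compound 3 (1.79 log units; beyond the scatter) is expected to be reversed. Among the measured compounds shown here, no measured step compares methyl with trifluoromethyl, which leaves the size of the recovery uncertain. A large move toward a lower number is therefore expected, estimated as an at least 25-fold lower number from compound 3 to compound 4 (1.39 log units; beyond the scatter). For compound 4 the estimated value is 4000 nM, with an expected range from 1200 nM to 14000 nM.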

Compound 4, half-maximal inhibitory concentration: 1000 nM
Estimate against measurement, compound 4: 4.0-fold (0.60 log units) above, outside the stated range (below it).
By their numbers in this assay, from the lowest: compounds 4 and 1 (each within the scatter of the next); then compound 2. At a limit, above all of these: compound 3.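

In this assay, among these compounds, the step to methyl in place of trifluoromethyl on an aromatic carbon, a 1.6-fold lower number from compound 1 to compound 4 (0.20 log units; within the scatter), is a change that cannot be told from the scatter, so at this amine nitrogen 3-methylphenyl and 3-(trifluoromethyl)phenyl read alike, something no earlier compound could show. The same 3-methylphenyl group also stands well apart from the two other groups: 4-acetylphenyl gives way to it with a 21-fold lower number from compound 2 to compound 4 (1.32 log units; beyond the scatter), and 4-carboxyphenyl with an at least 100-fold lower number from compound 3 to compound 4 (2.00 log units; beyond the scatter), both large steps. Compound 3 is reported only as a limit and not as a number, so the last of these steps has a lower bound and no known size: (the limit of > 100000 nM in this assay, at which 1 of the 4 values shown sits).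

From the compounds shown here alone, what stays open is whether the higher numbers of compound 2 and compound 3 go with the acetyl and carboxy groups themselves or with the way these groups are placed on the phenyl ring. A 3-acetylphenyl or 3-carboxyphenyl group would separate these two readings, while an unsubstituted phenyl or a 3-chlorophenyl group would show how far the match between methyl and trifluoromethyl extends.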